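A few compounds are considered here, and "the series" means these few. Any claim that something is new, unique, unknown or untested is made for them only; others in the source may bear on it.

In a functional assay on SK-BR-3 cells (Homo sapiens) for cytotoxicity, read by MTT assay, with a stated time of 72 h (on this read-out higher numbers stand for weaker inhibition and lower numbers for stronger inhibition), three compounds have been measured so far:
compound 1, `N[C@H]1CC[C@H](Nc2c(C(=O)NCc3ccco3)nc(Br)c3cccnc23)CC1`, giving 10000 nM;
compound 2, `N[C@H]1CC[C@H](Nc2c(C(=O)NC3CCCCC3)nc(Br)c3cccnc23)CC1`, giving 4200 nM;
compound 3, `N[C@H]1CC[C@H](Nc2c(C(=O)NCc3ccccc3)nc(Br)c3cccnc23)CC1`, giving 8000 nM.

Compound 3 holds the second highest of the three numbers. Its nearest value is that of compound 1 and its furthest that of compound 2, yet both of those gaps sit within the scatter, so the three values cannot be set in a firm order. For the measured compounds named here, the only step that exceeds the scatter is a 2.4-fold lower number from compound 1 to compound 2 (0.38 log units; beyond the scatter), a modest one; a 1.3-fold lower number from compound 1 to compound 3 (0.10 log units; within the scatter) and a 1.9-fold higher number from compound 2 to compound 3 (0.28 log units; within the scatter) do not.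

Compound 4, `C[C@H](NC(=O)c1nc(Br)c2cccnc2c1N[C@H]1CC[C@H](N)CC1)c1ccc(F)cc1`, has not yet been measured. It differs from compound 3 in one place: 1-(4-fluorophenyl)ethyl in place of benzyl on an amide-type nitrogen. Going by the values given here, the steps that bear on this change are those that alter the same amide-type nitrogen substituent, a 1.9-fold higher number from compound 2 to compound 3 (0.28 log units; within the scatter) and a 1.3-fold lower number from compound 1 to compound 3 (0.10 log units; within the scatter), and neither leaves the scatter. No measured step introduces a fluorine or a defined stereocentre, so nothing shown speaks to those parts of the change. The expectation is therefore a step of no size beyond the scatter, a 1.3-fold lower number from compound 3 to compound 4 (0.12 log units; within the scatter). Compound 4 is estimated at 6000 nM, within a range from 2500 nM to 15000 nM.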

Compound 4, half-maximal inhibitory concentration: 9000 nM
Beside the measured number, compound 4's estimate is 1.5-fold (0.18 log units) below it; the measured number falls inside the stated range.
By their numbers in this assay, from the lowest: compounds 2, 3, 4 and 1 (each within the scatter of the next, the first and the last beyond it).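

In this assay, putting 1-(4-fluorophenyl)ethyl in place of benzyl on the amide-type nitrogen gives a 1.1-fold higher number from compound 3 to compound 4 (0.05 log units; within the scatter) and so shows that this substituent can take a fluorine, an added carbon and a defined stereocentre together without a step that leaves the scatter. Set against (furan-2-yl)methyl, the same group gives a 1.1-fold lower number from compound 1 to compound 4 (0.05 log units; within the scatter) and thus adds a third member to a set of aromatic substituents whose values all lie within the scatter of one another. Against cyclohexyl it gives a 2.1-fold higher number from compound 2 to compound 4 (0.33 log units; beyond the scatter) as a modest step, which makes compound 2 stand apart from compound 1 and compound 4, though not from compound 3, whose step from compound 2 stays within the scatter.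

The fluorine, the added carbon and the stereocentre entered in a single change. The compounds shown leave their separate contributions open, along with what the opposite stereocentre, a carboxylic acid or a longer chain would do on this nitrogen. Nothing given here accounts for these values or for the place of compound 2 among them.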